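Working notes: phenyl replaced by hydrogen on compound 2

The source may report more compounds than this note shows. Statements on the series, on what has been measured and on what is new or still open speak of the compounds shown alone.

Values so far in a physicochemical assay for acid dissociation, tested at 10 mM, for the series:
compound 1 `Cc1cc(SSc2cc(C)nn2-c2ccccc2)n(-c2ccccc2)n1` gives 4.8 here
compound 2 `Cc1cc(COc2cc(C)nn2-c2ccccc2)n(-c2ccccc2)n1` gives 2.7 here

Compound 2 holds the lower of the two numbers, and compound 1 at 4.8 lies beyond the scatter from it. Compound 3 `Cc1cc(OCc2cc(C)nn2-c2ccccc2)[nH]n1` carries hydrogen in place of phenyl on an aromatic nitrogen of the shared core. Within the data shown here, no measured pair shows this change alone, so the only guide is the span from compound 2 at 2.7 to compound 1 at 4.8 in this assay for now. The expected step is a number 0.80 log units higher from compound 2 to compound 3 (beyond the scatter) as a rise beyond the scatter, smaller than that span. Compound 3 is estimated at 3.5, with a range of 2.8 to 4.4 expected.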

Compound 3, acid dissociation constant: 2.4
For compound 3 the middle estimate is 1.10 log units above the measured one; measured number below the stated range.
By their numbers in this assay, from the lowest: compounds 3 and 2 (each within the scatter of the next); then compound 1.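

In this assay, among these compounds, hydrogen in place of phenyl on an aromatic nitrogen of the shared core gives a number 0.30 log units lower from compound 2 to compound 3 (within the scatter), the only step that differs in one place. For this pair, the read-out does not separate phenyl from hydrogen at this position, even though one six-membered aromatic ring of carbon only leaves. Nothing measured on these compounds speaks to a cause for this result.

From the compounds shown here alone, it remains open whether a carboxylic acid or an amine on this aromatic nitrogen would also stay within the scatter of compound 3. The same holds for the same change at the phenyl that remains in compound 3.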